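This account rests on a few compounds, and the source may have more. Where it says the series, first, only, none or still open, it means among the compounds named here.

The measured compounds:
compound 1, `Fc1ccc(-c2nnc3sc(/C=C/c4ccco4)nn23)cc1` — in an assay for inhibition of histone-lysine N-methyltransferase, H3 lysine-79 specific (Homo sapiens), read by scintillation counting, with stated times of 15 min and 60 min, tested at 50 uM, in the presence of a further agent that is not named here (a higher number here means a stronger effect of the compound at the concentration tested, a lower number a weaker effect), compound 1 gives 44%;
compound 2, `Fc1cccc(-c2nnc3sc(/C=C/c4ccco4)nn23)c1` — compound 2 gives 22%;
compound 3, `C(=C/c1nn2c(-c3ccccc3)nnc2s1)\c1ccco1` — compound 3 gives 79%.

Compound 3 stands highest of the three, shown by a number 35 percentage points higher from compound 1 to compound 3 (beyond the scatter) and a number 57 percentage points higher from compound 2 to compound 3 (beyond the scatter), both beyond the scatter. Compound 4, `CN(C)c1ccc(-c2nnc3sc(/C=C/c4ccco4)nn23)cc1`, differs from compound 3 by dimethylamino in place of hydrogen on an aromatic carbon. Among the compounds with values here, no measured step adds a group to the unsubstituted ring; the nearest guides are the two steps just named, where removing fluoro raised the number by a large margin, and a number 22 percentage points lower from compound 1 to compound 2 (beyond the scatter), where its position mattered modestly. Carrying a group on that ring has so far gone with a lower number, so a decrease is expected, though dimethylamino is not fluoro. This amounts to an expected step of a number 24 percentage points lower from compound 3 to compound 4 (beyond the scatter). Compound 4 is expected to give 55%, with a range from 30% to 80%.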

Compound 4, a percentage reported as inhibition, at one concentration (the size of the read-out at that concentration, not a potency): 60%
The estimate for compound 4 lay 5 percentage points below the measured number, within the range that was stated.
By their numbers in this assay, from the lowest: compound 2; then compound 1; then compound 4; then compound 3.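

With dimethylamino on the aromatic carbon para to a large group, the ring again carries a group other than hydrogen and the number falls, as it did with fluoro, shown by a number 19 percentage points lower from compound 3 to compound 4 (beyond the scatter) and a smaller loss than fluoro brought at that place. The group that enters therefore matters and not only its presence, since exchanging the two gives a number 16 percentage points higher from compound 1 to compound 4 (beyond the scatter) in this one comparison. No evidence is available that explains either step.

Going by these compounds, whether a primary amine or a carboxylic acid at this place would keep the number nearer that of compound 3 remains open.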